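The source may report more compounds than this note shows. Statements on the series, on what has been measured and on what is new or still open speak of the compounds shown alone.

Compound 1 `CCN(c1ccccc1C)S(=O)(=O)c1cc(Cl)ccc1Cl` — in an ADME assay on A549 cells (Homo sapiens) for cytotoxicity, read by MTT assay; on this read-out higher numbers stand for lower toxicity in this test and lower numbers for higher toxicity in this test: > 25000 nM
Compound 2 `C#CCN(c1ccccc1C)S(=O)(=O)c1cc(Cl)ccc1Cl` — in this assay: > 5000 nM

Compound 1 stands at a limit of this assay rather than at a number: its reading of > 25000 nM is the limit of > 25000 nM in this assay, at which 1 of the 2 values shown sits. Compound 2 likewise sits at a limit, (the limit of > 5000 nM in this assay, at which 1 of the 2 values shown sits). The step that the two limits leave unreadable from compound 1 to compound 2 therefore cannot be sized, since both ends are limits.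

Compound 3 `CCN(c1ccccc1C#N)S(=O)(=O)c1cc(Cl)ccc1Cl` differs from compound 1 by cyano in place of methyl on an aromatic carbon. Going by the values given here, no measured step touches this aromatic carbon; the one measured step, a step that the two limits leave unreadable from compound 1 to compound 2, alters the chain on the sulfonamide nitrogen and is itself unreadable. What the two measured compounds do show is that neither reaches a readable toxicity in this assay. On that basis compound 3 is expected to remain near compound 1, with a step of a number no higher from compound 1 to compound 3 (the limit leaves the size open) not beyond the scatter. Compound 3 is estimated at 25000 nM, in a range from 8000 nM to 60000 nM, most likely again reported as a limit.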

Compound 3, half-maximal cytotoxic concentration: > 5000 nM
Compound 3: only a limit was reported; the forecaster's own chance of this, stated with the estimate: 75%; the middle value lies beyond the limit too.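

Compound 1 and compound 3 both stand at limits rather than at numbers in this assay, and the step between them cannot be read. The compounds shown leave open what concentration, if any, gives a readable toxicity, and whether swapping methyl for cyano changes it.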